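The source may hold more compounds than are shown below. What is called first, only, known or untested is meant among the compounds shown, and "the series" means these compounds.

Three measured compounds share one core and differ only in their substituents. Compound 1 `O=C(Nc1ccc(Oc2ccnc3[nH]ccc23)cc1)c1cc2cccnc2n(-c2ccc(Br)cc2)c1=O` gives 270 nM in a functional assay on HT-29 cells (Homo sapiens) for antiproliferative activity, read by MTT assay, with a stated time of 72 h; on this read-out lower numbers stand for stronger inhibition and higher numbers for weaker inhibition. Compound 2 `O=C(Nc1ccc(Oc2ccnc3[nH]ccc23)c(F)c1)c1cc2cccnc2n(-c2ccccc2)c1=O` gives 160 nM in this assay. Compound 3 `O=C(Nc1ccc(Oc2ccnc3[nH]ccc23)c(F)c1)c1cc2cccnc2n(-c2ccc(F)cc2)c1=O` gives 36 nM in this assay, the lowest of the three numbers, with compound 2 nearest and compound 1 furthest. For the measured compounds named here, the only single-point step among them is a 4.4-fold lower number from compound 2 to compound 3 (0.65 log units; beyond the scatter), a fluoro in place of hydrogen on an aromatic carbon. Compound 1 differs from compound 2 in two places, so its higher number cannot be assigned to either change.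

Compound 4 `O=C(Nc1ccc(Oc2ccnc3[nH]ccc23)c(F)c1)c1cc2cccnc2n(-c2ccc(Br)cc2)c1=O` differs from compound 3 by bromo in place of fluoro on an aromatic carbon. Going by the values given here, no measured step exchanges fluoro for bromo. Among the compounds with values here, compound 1 is the only measured compound carrying bromo, and its number is the highest, but it also lacks the fluoro present in compounds 2 and 3, so it gives no clean reading of the bromo change by itself. With this thin evidence, compound 4 is expected to show a 2.2-fold higher number from compound 3 to compound 4 (0.35 log units; beyond the scatter) in this assay, a step toward a higher number that may remain within the scatter. Compound 4 is estimated at 80 nM in this assay, with a range from 25 nM to 300 nM.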

Compound 4, half-maximal inhibitory concentration: 120 nM
Estimate against measurement, compound 4: 1.5-fold (0.18 log units) below; the range from low to high includes it.
By their numbers in this assay, from the lowest: compound 3; then compounds 4, 2 and 1 (each within the scatter of the next, the first and the last beyond it).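

Set against hydrogen and fluoro, the bromo compound gives the first clean reading of a second halogen at this position, para to a large group. In this assay, the 4-fluorophenyl to 4-bromophenyl change gives a 3.3-fold higher number from compound 3 to compound 4 (0.52 log units; beyond the scatter), while bromo in place of hydrogen gives a 1.3-fold lower number from compound 2 to compound 4 (0.12 log units; within the scatter), so on this core fluoro separates from the unsubstituted phenyl and bromo does not. Compound 4 also supplies a second fluoro in place of hydrogen step, at a different place in the molecule, which gives a 2.3-fold lower number from compound 1 to compound 4 (0.35 log units; beyond the scatter) and runs in the same direction as the fluoro step at the position studied here: the same change on two cores in this assay, a 4.4-fold lower number (0.65 log units; beyond the scatter) from compound 2 to compound 3 and a 2.3-fold lower number (0.35 log units; beyond the scatter) from compound 1 to compound 4, 2.0-fold (0.30 log units) apart, within the scatter of two such steps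

The compounds shown leave open how a chloro, a methoxy or an amine at this position would compare with fluoro and bromo, so two halogens and hydrogen are all that can be read there. They also leave open whether the gap between fluoro and bromo would persist on a core without the fluoro that compounds 2, 3 and 4 share, since compound 1 is the only compound lacking it and no fluoro partner for it is shown.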